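This account rests on a few compounds, and the source may have more. Where it says the series, first, only, none or still open, it means among the compounds named here.

In a functional assay on MCF7 cells (Homo sapiens) for inhibition, with a stated time of 48 h (a higher number here means a weaker inhibitor, a lower number a stronger inhibitor), compound 1 (`COc1cc(Sc2c[nH]c3ccccc23)cc(OC)c1OC`) gives 34 nM as its half-maximal inhibitory concentration. In this assay compound 2 (`COc1cc(Sc2c(C)[nH]c3ccccc23)cc(OC)c1OC`) gives 46 nM and the two differ by a 1.4-fold higher number from compound 1 to compound 2 (0.13 log units; within the scatter) so they stand level at the low end of the numbers. Compound 3 (`COc1ccccc1Sc1c[nH]c2ccc(Cl)cc12`) is reported only as a limit of > 2500 nM in this assay and gives no number to compare.

Compound 4 (`COc1cc(Sc2c[nH]c3ccc(Br)cc23)cc(OC)c1OC`) has not yet been measured. It differs from compound 1 by a single change, bromo in place of hydrogen on an aromatic carbon, counted as bromo in place of hydrogen on an aromatic carbon with the rest of the core untouched. Going by the values given here, only one measured step involves a single change of this kind, a 1.4-fold higher number from compound 1 to compound 2 (0.13 log units; within the scatter) for methyl in place of hydrogen on an aromatic carbon. Among the compounds with values here, that step brings a different group, and no measured step isolates bromo, so it offers only weak guidance. Even so, it suggests that a small substituent need not shift the number much in this assay and only a modest rise is expected. The estimated change is a 1.8-fold higher number from compound 1 to compound 4 (0.25 log units; within the scatter) with nothing beyond the scatter anticipated. For compound 4 the estimated value is 60 nM with an expected range from 15 nM to 250 nM in this assay before any measurement is known.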

Compound 4, half-maximal inhibitory concentration: 43 nM
Beside the measured number, compound 4's estimate is 1.4-fold (0.14 log units) above it; measured number inside the range.
By their numbers in this assay, from the lowest: compounds 1, 4 and 2 (each within the scatter of the next). At a limit, above all of these: compound 3.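

This is the first single change shown on the six-membered aromatic ring of carbon only, at the carbon meta to a fused ring and para to a fused ring. In this assay the step is a 1.3-fold higher number from compound 1 to compound 4 (0.10 log units; within the scatter) and so bromo, a single heavy atom that brings no hydrogen-bond donor or acceptor, takes the place of hydrogen here without a shift beyond the scatter. Going by these compounds alone, the only earlier step, a 1.4-fold higher number from compound 1 to compound 2 (0.13 log units; within the scatter) for methyl on a different aromatic carbon, showed the same for one other place on the core of compound 1, and nothing given here bears on why the number holds at the bromo position.

Going by these compounds, what stays open is whether this carbon accepts groups of a different kind, such as an amine, a carboxylic acid or a longer chain like butoxy, with the number still within the scatter of compound 1. Also open, on these data alone, is whether bromo and methyl, carried together on the core of compound 1, would leave the number as each does alone.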